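The source may hold more compounds than are shown below. What is called first, only, known or untested is meant among the compounds shown, and "the series" means these compounds.

Measured in a functional assay on RAW264.7 cells (Mus musculus) for inhibition, read by Griess assay, with stated times of 1 h and 24 h; on this read-out lower numbers stand for stronger inhibition and higher numbers for weaker inhibition:

Compound 1 `COc1ccc(C(O)C2OC(=O)c3c(OC)cc(OC)cc32)cc1`: > 10000 nM, a limit of the assay
Compound 2 `COc1cc(OC)c2c(c1)C(C(O)c1ccc(OCc3ccc(Br)cc3)cc1)OC2=O`: 6530 nM
Compound 3 `COc1cc(OC)c2c(c1)C(C(O)c1ccc(OCc3ccc(OC(F)F)cc3)cc1)OC2=O`: 5030 nM

For the measured compounds named here, compound 3 shares its place with the only other exact number in the set, as a 1.3-fold lower number from compound 2 to compound 3 (0.11 log units; within the scatter) shows. The next compound, compound 4 `COc1cc(OC)c2c(c1)C(C(O)c1ccc(OCC3CCCCC3)cc1)OC2=O`, carries cyclohexyl in place of 4-(difluoromethoxy)phenyl on a saturated chain carbon bound to an oxygen on an aromatic ring.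

Going by the values given here, three measured steps bear on this change. Two add a substituted phenyl at that same place, an at least 1.5-fold lower number from compound 1 to compound 2 (0.18 log units; that floor lies within the scatter) and an at least 1.9-fold lower number from compound 1 to compound 3 (0.29 log units; that floor lies within the scatter). Both are only floors, set by the limit of > 10000 nM in this assay, at which 1 of the 3 values shown sits. The third changes the group on that phenyl, and a 1.3-fold lower number from compound 2 to compound 3 (0.11 log units; within the scatter) stays small. Among the compounds with values here, no measured step replaces the aromatic ring with a non-aromatic one, so the forecast is loose. Since the swap on compound 3 gave only a 1.3-fold lower number from compound 2 to compound 3 (0.11 log units; within the scatter), no shift beyond the scatter is foreseen. The expected step is a 1.2-fold higher number from compound 3 to compound 4 (0.08 log units; within the scatter). For compound 4 the estimated value is 6000 nM, with an expected range of 2500 nM to 14000 nM.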

Compound 4, half-maximal inhibitory concentration: > 10000 nM
Compound 4: a limit, no number; the forecaster's own chance of this, stated with the estimate: 25%; middle value at least 1.6-fold (0.22 log units) away from the limit.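

In this assay compound 4 gives > 10000 nM, which is a limit and not a number. For the compounds shown here, this is the first non-aromatic ring measured at this place, and the result gives only floors, an at least 1.9-fold higher number from compound 3 to compound 4 (0.29 log units; that floor lies within the scatter) and an at least 1.5-fold higher number from compound 2 to compound 4 (0.18 log units; that floor lies within the scatter), so cyclohexyl cannot be told apart from either substituted phenyl group. The step that joins the two limit values cannot be read, and the comparison at this place is bounded by a single limit: the limit of > 10000 nM in this assay, at which 2 of the 4 values shown sit.

Going by these compounds, how far compound 4 truly lies from compound 2 and compound 3 stays open. The compounds shown also leave open whether a longer chain in place of cyclohexylmethyl, or an amine or a carboxylic acid on the phenyl ring of 4-(difluoromethoxy)benzyl, would give an exact number in this assay.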